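Furan to Pyridine Swap on a Weakly Active Scaffold

The source may report more compounds than this note shows. Statements on the series, on what has been measured and on what is new or still open speak of the compounds shown alone.

Compound 1 `Oc1ccc(-c2cc(-c3ccccn3)nc(-c3ccccc3Cl)c2)cc1` in an assay on isolated protein for inhibition of DNA topoisomerase 1 (Homo sapiens), with a stated time of 30 min, tested at 100 uM (on this read-out lower numbers stand for a weaker effect and higher numbers for a stronger effect at the one concentration tested), gives 5.2%
Compound 2 `Oc1ccc(-c2cc(-c3ccco3)nc(-c3ccccc3Cl)c2)cc1` in this assay gives 3.9%

Both compounds barely register in this assay. Compound 2 has the smaller of the two figures, yet the step of a number 1.3 percentage points lower from compound 1 to compound 2 (within the scatter) lies within the scatter, so the two cannot be told apart. Compound 3 `Oc1ccc(-c2cc(-c3ccncc3)nc(-c3ccccc3Cl)c2)cc1` differs from compound 2 by pyridin-4-yl in place of furan-2-yl on an aromatic carbon. Among the compounds with values here, the one step that bears on this, a ring exchange at the same place, produced no change beyond the scatter, so compound 3 is expected to move by about a number 1.1 percentage points higher from compound 2 to compound 3 (within the scatter). Compound 3 is estimated at 5%, with a range from 0% to 15%.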

Compound 3, a percentage reported as inhibition, at one concentration (the size of the read-out at that concentration, not a potency): 9.9%
Compound 3: middle estimate off by 4.9 percentage points, on the low side, and the stated range covers the measured number.
By their numbers in this assay, from the lowest: compounds 2, 1 and 3 (each within the scatter of the next).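

Swapping in pyridin-4-yl for furan-2-yl gives a number 6 percentage points higher from compound 2 to compound 3 (within the scatter), and swapping it for pyridin-2-yl gives a number 4.7 percentage points higher from compound 1 to compound 3 (within the scatter), both in this assay. At this position, then, neither a six-membered ring in place of a five-membered one nor a different attachment point on the pyridine shifts the read-out beyond the scatter. No measurement here offers an explanation for these numbers. Still open, from the compounds shown here alone, is whether a group of another kind at this position, such as an amine or a carboxylic acid, would lift the read-out clearly above that of these three aromatic rings.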